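Cytotoxicity notes on the amine substituent of the shared core

The compounds below may be only part of what the source reports. "The series", "measured", "known", "first", "only" and "open" are said of these compounds alone.

Three analogues of one shared core have been measured. In a functional assay on HEL cells (Homo sapiens) for cytotoxicity, read by microscopy (a lower number here means that less compound is tolerated, a higher number that more compound is tolerated), compound 3 `COC(=O)CCNC1=CS(=O)(=O)O[C@@]12[C@@H](CO[Si](C)(C)C(C)(C)C)O[C@@H](n1cc(C)c(=O)n(C)c1=O)[C@@H]2O[Si](C)(C)C(C)(C)C` gives only a limit of the assay, >= 400000 nM. Compound 1 `Cc1cn([C@@H]2O[C@H](CO[Si](C)(C)C(C)(C)C)[C@@]3(OS(=O)(=O)C=C3NCCC(=O)OCc3ccccc3)[C@H]2O[Si](C)(C)C(C)(C)C)c(=O)n(C)c1=O` likewise gives only a limit, >= 400000 nM. Compound 2 `COC(=O)CNC1=CS(=O)(=O)O[C@@]12[C@@H](CO[Si](C)(C)C(C)(C)C)O[C@@H](n1cc(C)c(=O)n(C)c1=O)[C@@H]2O[Si](C)(C)C(C)(C)C` also gives only a limit, >= 400000 nM. Accordingly a step that the two limits leave unreadable from compound 1 to compound 2, a step that the two limits leave unreadable from compound 1 to compound 3 and a step that the two limits leave unreadable from compound 2 to compound 3 have no readable size; what the three share is the limit of >= 400000 nM in this assay, at which 3 of the 3 values shown sit. Compound 4 `C=C(C)C(=O)NC(=O)NC1=CS(=O)(=O)O[C@@]12[C@@H](CO[Si](C)(C)C(C)(C)C)O[C@@H](n1cc(C)c(=O)n(C)c1=O)[C@@H]2O[Si](C)(C)C(C)(C)C` differs from compound 3 by ((1-methylethenyl)carbonyl)carbamoyl in place of 2-(methoxycarbonyl)ethyl on an amine nitrogen. Among the compounds with values here, no measured step gives a readable size for this change, so no step beyond the scatter is expected in this assay. Compound 4 is therefore expected near 400000 nM, in the range 200000 nM to 400000 nM, most probably again reported as a limit. That estimate means an expected step of a number no higher from compound 3 to compound 4 (the limit leaves the size open).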

Compound 4, minimum cytotoxic concentration: 20000 nM
Compound 4: the middle estimate sits 20-fold (1.30 log units) above what was measured; measured number outside the range, below it.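

In this assay, the amine nitrogen of the shared core now gives a readable change: ((1-methylethenyl)carbonyl)carbamoyl brings an at least 20-fold lower number from compound 3 to compound 4 (1.30 log units; beyond the scatter), an at least 20-fold lower number from compound 2 to compound 4 (1.30 log units; beyond the scatter) and an at least 20-fold lower number from compound 1 to compound 4 (1.30 log units; beyond the scatter). Each of these steps is a lower bound on the size, and the steps among compounds 1, 2 and 3 cannot be read. Those three ester chains rest on one assay limit, so this position is not shown to be insensitive: the limit of >= 400000 nM in this assay, at which 3 of the 4 values shown sit.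

The compounds shown leave open whether the step belongs to the 1-methylethenyl end or to the carbonyl-carbamoyl link. An isopropyl end in place of 1-methylethenyl would separate the two.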